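The compounds below may be only part of what the source reports. "The series", "measured", "known", "first", "only" and "open" are said of these compounds alone.

Measured so far in an ADME assay on HEK293 cells (Homo sapiens) for cytotoxicity, read by CellTiter-Glo and resazurin assay, with a stated time of 72 h; a lower number here means that less compound is needed, a higher number that more compound is needed for the effect:

Compound 1 `CCCNCc1ccccc1OCCCCCC(=O)OCC` gives > 26000 nM, which is a limit of the assay and not a number.
Compound 2 `CCCNCc1cccc(OCCCCCC(=O)OCC)c1` gives > 26000 nM, again a limit of the assay.
Compound 3 `CCOC(=O)CCCCCOc1ccccc1C=O` gives > 26000 nM, also a limit of the assay.

The open question is compound 4 `CCOC(=O)CCCCCOc1cccc(C=O)c1`, which is not yet measured. Compound 3 arises from compound 1 by the change (formyl in place of (propylamino)methyl on an aromatic carbon). The step that the two limits leave unreadable from compound 1 to compound 3 cannot be read because both values sit at the limit of > 26000 nM in this assay, at which 3 of the 3 values shown sit. How the core of compound 2 differs from the core of compound 1 is not broken down here. Compound 4 arises from compound 2 by the change (formyl in place of (propylamino)methyl on an aromatic carbon). Within the data shown here, this is the same kind of change as the one from compound 1 to compound 3, not the same one: there the place was ortho to a large group, here it is meta to a large group.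

The expectation for the step from compound 2 to compound 4 is a step that the limit leaves unreadable from compound 2 to compound 4, and it rests only on the three values sitting at the limit of > 26000 nM in this assay, at which 3 of the 3 values shown sit. Compound 4 is therefore expected to give about 40000 nM, most likely reported again only as a limit, with a range from 20000 nM to 120000 nM.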

Compound 4, half-maximal effective concentration: > 26000 nM
Compound 4: no number, only a limit; the forecaster's own chance of this, stated with the estimate: 85%; the middle value lies beyond the limit too.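

No size can be read for the step from compound 2 to compound 4, formyl in place of (propylamino)methyl, and no other comparison here gives one either: the limit of > 26000 nM in this assay, at which 4 of the 4 values shown sit.

The compounds shown leave open what concentration any of them needs for the effect in this assay, and whether any change to the shared core gives a number instead of a limit.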